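A Chloro Substituent on a Compound at the Assay Limit

A few compounds are considered here, and "the series" means these few. Any claim that something is new, unique, unknown or untested is made for them only; others in the source may bear on it.

Compound 1 `O=C1Nc2ccc(F)cc2/C1=N/NC(=S)N1CCN(c2ccccc2)CC1` and compound 2 `O=C1Nc2ccccc2/C1=N/NC(=S)Nc1ccccc1` share a core but differ at two places. In a functional assay on HCT-116 cells (Homo sapiens) for inhibition, read by MTT assay, with a stated time of 72 h (a higher number here means a weaker inhibitor, a lower number a stronger inhibitor), compound 1 gives 12400 nM. For compound 2 the result in this assay is only a limit of the assay, > 100000 nM. Compound 2 therefore stands at the limit of > 100000 nM in this assay, at which 1 of the 2 values shown sits, the furthest point the measurement reaches. Compound 3 `O=C1Nc2ccc(Cl)cc2/C1=N/NC(=S)Nc1ccccc1` keeps everything of compound 2 and adds (chloro in place of hydrogen on an aromatic carbon). Among the compounds with values here, no measured pair in this set shows what such a change does, so only a cautious expectation is possible. The expected step is an at least 1.6-fold lower number from compound 2 to compound 3 (0.22 log units; that floor lies within the scatter), in the direction of a stronger inhibitor, although it may just as well stay within the scatter. Compound 3 is thus expected to give about 60000 nM in this assay, with a likely range from 15000 nM to 200000 nM.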

Compound 3, half-maximal inhibitory concentration: 30800 nM
For compound 3 the middle estimate is 1.9-fold (0.29 log units) above the measured one, within the range that was stated.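

In this assay, chloro in place of hydrogen on an aromatic carbon of the fused system of two rings gives an at least 3.2-fold lower number from compound 2 to compound 3 (0.51 log units; beyond the scatter). Within the data shown here, this is the first pair here that differs in one place only, so this single change can be read on its own, which compound 1 and compound 2, differing at two places, could not offer. The step gives only the smallest possible size of the change and not its exact size, because one end of it rests on an assay limit: the limit of > 100000 nM in this assay, at which 1 of the 3 values shown sits.

Going by these compounds, whether a bromo, a methyl or a methoxy group at this same position would give a similar step remains open. Also open, on these data alone, is whether chloro would act in the same way on compound 1, which differs from compound 3 in more than this one place.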